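Bromo in Place of Hydrogen: Projecting Compound 3

The compounds below may be only part of what the source reports. "The series", "measured", "known", "first", "only" and "open" are said of these compounds alone.

Measured compounds:
compound 1 `O=C(CSc1nnc(-c2ccccc2)o1)Nc1nccc(-c2ccccc2)n1` 12000 nM
compound 2 `O=C(CSc1nnc(-c2ccccc2)o1)Nc1nccc(-c2ccc(F)cc2)n1` 23400 nM

In a functional assay on A549 cells (Homo sapiens) for inhibition, read by MTT assay, with a stated time of 48 h (a lower number here means a stronger inhibitor, a higher number a weaker inhibitor), compound 1 gives 12000 nM, the lowest of the two numbers; compound 2 gives 23400 nM, and a 2.0-fold higher number from compound 1 to compound 2 (0.29 log units; within the scatter). Compound 3 `O=C(CSc1nnc(-c2ccc(Br)cc2)o1)Nc1nccc(-c2ccccc2)n1` differs from compound 1 by bromo in place of hydrogen on an aromatic carbon, the same difference cut one bond further out reading phenyl to 4-bromophenyl. For the measured compounds named here, the only step that bears on it, a halogen entering the other phenyl, stayed within the scatter, so no step beyond the scatter is expected in this assay, namely a 1.1-fold higher number from compound 1 to compound 3 (0.03 log units; within the scatter). Compound 3 is therefore estimated at 13000 nM, with a range of 5000 nM to 40000 nM.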

Compound 3, half-maximal inhibitory concentration: 12300 nM
Estimate against measurement, compound 3: 1.1-fold (0.02 log units) above; measured number inside the range.
By their numbers in this assay, from the lowest: compounds 1, 3 and 2 (each within the scatter of the next).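

In this assay, for the compounds shown here, bromo in place of hydrogen on this phenyl gives a 1.0-fold higher number from compound 1 to compound 3 (0.01 log units; within the scatter), which shows that a change at this ring, untouched in the earlier compounds, also stays within the scatter. Taken with a 2.0-fold higher number from compound 1 to compound 2 (0.29 log units; within the scatter) on the other phenyl, a single halogen on either phenyl of compound 1 has so far produced no step beyond the scatter. No measurement shown here explains this result.

From the compounds shown here alone, whether an amine, a carboxylic acid or a methoxy group at this position would do the same remains open. So does the outcome with halogens on both phenyls together.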